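A 4-iodophenyl urea expected from two close neighbours

The source may report more compounds than this note shows. Statements on the series, on what has been measured and on what is new or still open speak of the compounds shown alone.

Two ureas built on the same core are measured. Compound 1 `Cc1nc2ccccc2c(=O)n1NC(=O)Nc1ccc(Cl)cc1` gives 48% in a functional assay on the whole organism for inhibition, with Mus musculus as the target, with a stated time of 1 h, at a dose of 100 mg/kg by the intraperitoneal route; on this read-out higher numbers stand for more inhibition at the one dose given (going by the name of the read-out) and lower numbers for less inhibition. Compound 2 `Cc1cccc(NC(=O)Nn2c(C)nc3ccccc3c2=O)c1` gives 51% in the same this assay, and the step of a number 3 percentage points higher from compound 1 to compound 2 (within the scatter) is within the scatter, so compound 2 stands level with compound 1 on the numbers at hand, with no ordering between them. Compound 3 `Cc1nc2ccccc2c(=O)n1NC(=O)Nc1ccc(I)cc1` is not yet measured. It differs from compound 2 by 4-iodophenyl in place of 3-methylphenyl on an amide-type nitrogen. Going by the values given here, the only step that bears on this change is a number 3 percentage points higher from compound 1 to compound 2 (within the scatter), in which a 4-substituted phenyl and a 3-methylphenyl on that nitrogen gave numbers within the scatter of each other. Compound 3 is therefore expected to move by a number 1 percentage points lower from compound 2 to compound 3 (within the scatter), that is, no step beyond the scatter. The estimate for compound 3 in this assay is 50%, with a range from 35% to 65%.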

Compound 3, a percentage reported as inhibition, in the whole organism at one dose (the size of the read-out at that dose, not a potency): 53%
The estimate for compound 3 lay 3 percentage points below the measured number; measured number inside the range.
By their numbers in this assay, from the lowest: compounds 1, 2 and 3 (each within the scatter of the next).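

Iodo in place of chloro on an aromatic carbon gave a number 5 percentage points higher from compound 1 to compound 3 (within the scatter) in this assay and so, unlike the earlier pair, this is a change of halogen alone on the 4-substituted phenyl. 4-Iodophenyl in place of 3-methylphenyl on the amide-type nitrogen gave a number 2 percentage points higher from compound 2 to compound 3 (within the scatter) and, with all the steps among the three compounds inside the scatter, the three aryl ureas stand level, with no order among them. Nothing on hand offers a reason for this result.

As far as these compounds go, all three compounds carry a substituted phenyl on that nitrogen, so it stays open whether a cyclohexyl group, a longer alkyl chain or a phenyl bearing a carboxylic acid or an amine would keep the number. A single dose also leaves the potency of these compounds unknown.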